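A few compounds are considered here, and "the series" means these few. Any claim that something is new, unique, unknown or untested is made for them only; others in the source may bear on it.

Measured so far:
compound 1 `COC(=O)N(CCO)c1c(N)nc(-c2nn(Cc3ccccc3F)c3ncccc23)nc1N` gives 0.3 uM in an assay on cells for activation of Guanylate cyclase soluble subunit alpha-1 (Rattus norvegicus), read by cGMP accumulation and immunoassay, with a stated time of 10 min; a higher number here means that more compound is needed for the effect, a lower number that less compound is needed;
compound 2 `CC(C)OC(=O)Nc1c(N)nc(-c2nn(Cc3ccccc3F)c3ncccc23)nc1N` gives 0.8 uM in this assay;
compound 3 `Nc1nc(-c2nn(Cc3ccccc3F)c3ncccc23)nc(N)c1NC(=O)OC1COC1` gives 2.3 uM in this assay.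

Compound 3 stands at the highest number of the three, needing the most compound for the effect; its nearest neighbour is compound 2, and compound 1 lies furthest from it. The new compound 4 `Nc1nc(-c2nn(Cc3ccccc3F)c3ncccc23)nc(N)c1N1CCOC1=O` differs from compound 3 at the carbamate position: 2-oxo-1,3-oxazolidin-3-yl in place of (((oxetan-3-yl)oxy)carbonyl)amino on an aromatic carbon.

Among the compounds with values here, three measured steps bear on this position. The change from the (2-hydroxyethyl)(methoxycarbonyl)amino group of compound 1 to the isopropoxycarbonyl amino group of compound 2 gave a 2.7-fold higher number from compound 1 to compound 2 (0.43 log units; beyond the scatter), and to the oxetanyloxycarbonyl amino group of compound 3 gave a 7.7-fold higher number from compound 1 to compound 3 (0.88 log units; beyond the scatter); between the two carbamates bearing an amide hydrogen the step was a 2.9-fold higher number from compound 2 to compound 3 (0.46 log units; beyond the scatter). Within the data shown here, all changes here have stayed modest, and the ring-closed carbamate of compound 4 shares with compound 1 the absence of an amide hydrogen, the only compound at the lowest number. For compound 4 the expected step is therefore a 3.3-fold lower number from compound 3 to compound 4 (0.52 log units; beyond the scatter), a modest move toward the range of compounds 1 and 2. The estimate for compound 4 is 0.7 uM, with a range of 0.2 uM to 2.5 uM.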

Compound 4, minimum effective concentration: 0.3 uM
Compound 4: the middle estimate sits 2.3-fold (0.37 log units) above what was measured; low and high end bracket the measured number.
By their numbers in this assay, from the lowest: compounds 1 and 4 (each within the scatter of the next); then compound 2; then compound 3.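

In this assay, the ring-closed 2-oxo-1,3-oxazolidin-3-yl group gives a 7.7-fold lower number from compound 3 to compound 4 (0.88 log units; beyond the scatter) and also a 2.7-fold lower number from compound 2 to compound 4 (0.43 log units; beyond the scatter) so it separates from both carbamates that keep the amide hydrogen. Against the open (2-hydroxyethyl)(methoxycarbonyl)amino group it shows no change at the digits printed from compound 1 to compound 4 (within the scatter) so, on this core, the open hydroxyethyl chain is not required to reach the level of compound 1, and the two compounds lacking the amide hydrogen are the two at the low end of the series. Nothing available explains these steps.

Still open, going by these compounds, is whether the ring oxygen matters, which a pyrrolidin-2-one at this position would address. Also open, on these data alone, is whether a simple methyl on the carbamate nitrogen of compound 2 would be enough, without any ring or hydroxyethyl chain.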